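The source may report more compounds than this note shows. Statements on the series, on what has been measured and on what is new or still open speak of the compounds shown alone.

Measured so far:
- compound 1 `COc1cc2oc(-c3cccc(NC(=O)c4ccc(C(F)(F)F)cc4)c3)cc(=O)c2c(OC)c1OC`: "active" (no number reported)
- compound 2 `COc1cc2oc(-c3cccc(NC(=O)c4ccc(Cl)cc4)c3)cc(=O)c2c(OC)c1OC`: 51.1%
- compound 3 `COc1cc2oc(-c3cccc(NC(=O)c4cccc(C#N)c4)c3)cc(=O)c2c(OC)c1OC`: "active" (no number reported)

All three share one core and differ only in the group carried on the amide. Going by the values given here, in a functional assay on UO-31 cells (Homo sapiens) for inhibition, read by sulforhodamine B assay, tested at 10 uM (on this read-out lower numbers stand for less inhibition and higher numbers for more inhibition at the one concentration tested (going by the name of the read-out)), compound 2 gives 51.1%, and this is the only number in the set; in this assay compound 1 gives "active" (no number reported) and compound 3 gives "active" (no number reported), so no comparison of size between them and compound 2 can be drawn.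

Compound 4 `COc1cc2oc(-c3cccc(NC(=O)c4ccc([N+](=O)[O-])cc4)c3)cc(=O)c2c(OC)c1OC` has not been measured yet. It is compound 2 with one change: nitro in place of chloro on an aromatic carbon. Among the compounds with values here, no pair of measured compounds shows a step of this kind, so there is nothing in the set that tells how large an effect to expect. The expectation is therefore a step of a number 3.1 percentage points lower from compound 2 to compound 4 (within the scatter) in this assay, which is none beyond the usual scatter. For compound 4 a value of 48% is expected in this assay, with a range from 25% to 70%.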

Compound 4, a percentage reported as inhibition, at one concentration (the size of the read-out at that concentration, not a potency): "active" (no number reported)
Nothing numeric was reported for compound 4; no gap can be computed for the estimate.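

Compound 4 gives "active" (no number reported) in this assay and compound 2 gives 51.1% there, so no step between them can be read, and nothing shown bears on the result. The compounds shown leave open how much swapping chloro for nitro changes inhibition.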